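The source may report more compounds than this note shows. Statements on the series, on what has been measured and on what is new or still open speak of the compounds shown alone.

Of the compounds shown here, three built on one shared core have been tested in a functional assay on T98G cells (Homo sapiens) for cytotoxicity, read by MTT assay, with a stated time of 48 h; a higher number here means a weaker inhibitor, a lower number a stronger inhibitor. Compound 1 `C/C(=N/NC(=S)Nc1ccccc1I)c1ccccn1` gives 8.09 nM, the highest of the three numbers. Compound 2 `C/C(=N/NC(=S)Nc1ccccc1[N+](=O)[O-])c1ccccn1` gives 6.61 nM; the step of a 1.2-fold lower number from compound 1 to compound 2 (0.09 log units; within the scatter) lies within the scatter, so the numbers of these two compounds cannot be told apart. Compound 3 `C/C(=N/NC(=S)Nc1ccccc1Cl)c1ccccn1` gives 1.1 nM; the step of a 7.4-fold lower number from compound 1 to compound 3 (0.87 log units; beyond the scatter) and the step of a 6.0-fold lower number from compound 2 to compound 3 (0.78 log units; beyond the scatter) both lie beyond the scatter, and compound 3 is the furthest of the three from compound 1.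

Compound 4 `CC(=NNC(=S)Nc1ccccc1I)c1ccccn1` has exactly the same atoms and bonds as compound 1 and differs only in how the structure is drawn: the two compounds have the same atoms and bonds; at least one stereo element is drawn with a configuration in one of them and without one in the other: 1 of 1 stereo elements differ; a double bond is drawn Z in compound 1 and without a configuration in compound 4. Each of the measured steps swapped one group for another on an aromatic carbon, so none of them speaks to a change that touches only a drawn configuration; the same substance is effectively being described twice. The step from compound 1 to compound 4 is therefore expected to be a 1.0-fold higher number from compound 1 to compound 4 (0.00 log units; within the scatter), nothing beyond the scatter. Compound 4 is estimated at 8.1 nM, within a range from 3.5 nM to 19 nM.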

Compound 4, half-maximal inhibitory concentration: 8.1 nM
The estimate for compound 4 equals the measured number at the digits printed; the measured number falls inside the stated range.
By their numbers in this assay, from the lowest: compound 3; then compounds 2, 1 and 4 (each within the scatter of the next).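

For the compounds shown here, the step of a 1.0-fold higher number from compound 1 to compound 4 (0.00 log units; within the scatter) is the first one here that leaves every atom and bond in place, whereas each earlier step swapped one group for another on an aromatic carbon. It shows that in this assay, drawing the double bond with or without a configuration goes with no readable difference in the number. Only one thing separates this pair: the fact that one of compounds 1 and 4 is drawn with a defined configuration and the other without, at the place where they differ

From the compounds shown here alone, a structure drawn without a configuration does not tell whether the sample holds one form or a mixture, so the effect of a double bond truly fixed the other way remains unknown. Also open, going by these compounds, is how the number would respond to a methoxy group or an amine in place of the iodo group on the aromatic carbon.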